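Replacing the dimethylamino group of compound 3

A few compounds are considered here, and "the series" means these few. Any claim that something is new, unique, unknown or untested is made for them only; others in the source may bear on it.

Measured in a functional assay on A549 cells (Homo sapiens) for antiproliferative activity, read by MTT assay, with a stated time of 48 h; on this read-out lower numbers stand for stronger inhibition and higher numbers for weaker inhibition:
- compound 1 `CC(=O)OC/C1=C/C[C@](C)(CCC=C(C)C)/C=C/[C@@H](OC(=O)C=C(C)C)[C@](C)(OC(C)=O)/C=C/C1=O`: 15100 nM
- compound 2 `COC/C1=C/C[C@](C)(CCC=C(C)C)/C=C/[C@@H](OC(=O)C=C(C)C)[C@](C)(OC)/C=C/C1=O`: 4180 nM
- compound 3 `CC(C)=CCC[C@]1(C)/C=C/[C@@H](OC(=O)C=C(C)C)[C@](C)(O)/C=C/C(=O)/C(CN(C)C)=C\C1`: 590 nM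

Compound 3 has the lowest number of the three, and both others lie above it, beyond the scatter. Compound 4 `CC(C)=CCC[C@]1(C)/C=C/[C@@H](OC(=O)C=C(C)C)[C@](C)(O)/C=C/C(=O)/C(COC(=O)c2ccc([N+](=O)[O-])cc2)=C\C1` carries ((4-nitrophenyl)carbonyl)oxy in place of dimethylamino on a saturated chain carbon bound to a double-bonded ring carbon. Among the compounds with values here, no measured pair isolates this change. Neither compound 1 at 15100 nM nor compound 2 at 4180 nM carries dimethylamino, but both also differ elsewhere, so they offer only loose guidance. The expected change is a 5.1-fold higher number from compound 3 to compound 4 (0.71 log units; beyond the scatter), toward weaker inhibition and beyond the scatter. For compound 4 the estimated value is 3000 nM, with an expected range of 800 nM to 11000 nM.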

Compound 4, half-maximal inhibitory concentration: 1310 nM
Compound 4: the middle estimate sits 2.3-fold (0.36 log units) above what was measured; the measured number falls inside the stated range.
By their numbers in this assay, from the lowest: compound 3; then compound 4; then compound 2; then compound 1.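

In this assay, swapping dimethylamino for ((4-nitrophenyl)carbonyl)oxy on a saturated chain carbon bound to a double-bonded ring carbon gives a 2.2-fold higher number from compound 3 to compound 4 (0.35 log units; beyond the scatter) and so a modest move toward weaker inhibition. Within the data shown here, this is the first one-place comparison at this position: a much larger group with a six-membered aromatic ring costs only a modest loss, and dimethylamino is not essential for activity in the micromolar range. No measured evidence bears on the reason for this step. The compounds shown leave open whether another amine, such as piperidine, would match dimethylamino here. They also leave open how a carboxylic acid would fare at this position.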